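From Propanoyl to a Lactam-Bearing Acyl Group

A few compounds are considered here, and "the series" means these few. Any claim that something is new, unique, unknown or untested is made for them only; others in the source may bear on it.

Compound 2 `CCC(=O)N1C[C@@H](O[C@H](C)c2cc(C(F)(F)F)cc(C(F)(F)F)c2)[C@H](c2ccc(F)cc2)C1` holds the lowest of the three numbers in an assay on CHO cells for displacement of a labelled ligand from Substance-P receptor (Homo sapiens) (a lower number here means a stronger inhibitor, a higher number a weaker inhibitor), where compound 2 gives 0.09 nM. Compound 3 `C[C@@H](O[C@@H]1CN(C(=O)C(C)(C)C)C[C@H]1c1ccccc1)c1cc(C(F)(F)F)cc(C(F)(F)F)c1` lies within the scatter of it, giving 0.18 nM in this assay, while compound 1 `C[C@@H](O[C@@H]1CN(C=O)C[C@H]1c1ccc(F)cc1)c1cc(C(F)(F)F)cc(C(F)(F)F)c1` gives 0.24 nM. Compound 4 `C[C@@H](O[C@@H]1CN(C(=O)[C@@H]2CCC(=O)N2C)C[C@H]1c1ccc(F)cc1)c1cc(C(F)(F)F)cc(C(F)(F)F)c1` carries 1-methyl-5-oxopyrrolidin-2-yl in place of ethyl on a carbonyl carbon. Among the measured compounds shown here, the only measured step at that carbonyl carbon is a 2.7-fold lower number from compound 1 to compound 2 (0.43 log units; beyond the scatter); no step joins compound 3 to compound 2, and its value merely shows that a larger acyl group is also well tolerated there. Because the step of a 2.7-fold lower number from compound 1 to compound 2 (0.43 log units; beyond the scatter) was modest, the author expects compound 4 to stay close to compound 2, with a 2.2-fold higher number from compound 2 to compound 4 (0.35 log units; beyond the scatter) at most. For compound 4 the estimate is 0.2 nM, ranging from 0.06 nM to 0.7 nM.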

Compound 4, half-maximal inhibitory concentration: 0.12 nM
Beside the measured number, compound 4's estimate is 1.7-fold (0.22 log units) above it, within the range that was stated.
By their numbers in this assay, from the lowest: compounds 2, 4, 3 and 1 (each within the scatter of the next, the first and the last beyond it).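

In this assay putting 1-methyl-5-oxopyrrolidin-2-yl in place of ethyl on a carbonyl carbon gives a 1.3-fold higher number from compound 2 to compound 4 (0.12 log units; within the scatter) and so shows that this position takes a five-membered ring with a hydrogen-bond acceptor and a defined stereocentre without a change that stands out from the scatter. With hydrogen as the starting point, the same group gives a 2.0-fold lower number from compound 1 to compound 4 (0.30 log units; within the scatter) and so cannot be told apart from the formyl compound either. Nothing available explains this tolerance. Open, on these data alone, is whether an acyl group bearing an amine or a carboxylic acid, or the opposite stereocentre of the 1-methyl-5-oxopyrrolidin-2-yl group, would fare alike.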